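Chloro to cyano on the pyridin-2-yl group: compound 3

The source may hold more compounds than are shown below. What is called first, only, known or untested is meant among the compounds shown, and "the series" means these compounds.

Compound 1 `O=C(CCCc1ccc(F)cn1)N1CCc2c(Cl)c(O)c(O)c(Cl)c2C1`: in a functional assay (Homo sapiens), tested at 1 uM (on this read-out lower numbers stand for a stronger effect and higher numbers for a weaker effect at the one concentration tested), compound 1 gives 89%.
Compound 2 `O=C(CCCc1ccc(Cl)cn1)N1CCc2c(Cl)c(O)c(O)c(Cl)c2C1`: in this assay compound 2 gives 85%.

Among the compounds with values here, the only measured step is a number 4 percentage points lower from compound 1 to compound 2 (within the scatter), so compound 2 sits together with compound 1 inside the scatter. Compound 3 `N#Cc1ccc(CCCC(=O)N2CCc3c(Cl)c(O)c(O)c(Cl)c3C2)nc1` carries cyano in place of chloro on an aromatic carbon. Within the data shown here, no measured step exchanges a halogen for cyano; the one step at this aromatic carbon, a number 4 percentage points lower from compound 1 to compound 2 (within the scatter), stays within the scatter, so no move beyond the scatter is expected in this assay, and the expected step is a number 1 percentage points lower from compound 2 to compound 3 (within the scatter). Compound 3 is therefore estimated at 84%, between 70% and 97%.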

Compound 3, a percentage reported as activity, at one concentration (the size of the read-out at that concentration, not a potency): 86%
The estimate for compound 3 lay 2 percentage points below the measured number, within the range that was stated.
By their numbers in this assay, from the lowest: compounds 2, 3 and 1 (each within the scatter of the next).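

In this assay, cyano in place of chloro gives a number 1 percentage points higher from compound 2 to compound 3 (within the scatter), and cyano in place of fluoro gives a number 3 percentage points lower from compound 1 to compound 3 (within the scatter). This aromatic carbon therefore now carries a group beyond the halogens, a nitrile with one hydrogen-bond acceptor, and fluoro, chloro and cyano cannot be told apart on this read-out. No available evidence explains why the three groups read alike.

On these data alone, whether an amine, a carboxylic acid or a methoxy group on this carbon would move the read-out beyond the scatter remains open.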